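The compounds below may be only part of what the source reports. "The series", "measured", "known", "first", "only" and "open" are said of these compounds alone.

Measured in a functional assay on MM1.S cells (Homo sapiens) for antiproliferative activity, read by MTT assay, with a stated time of 72 h; on this read-out lower numbers stand for stronger inhibition and higher numbers for weaker inhibition:
Compound 1 `CCOC(=O)C1=C(C)N=C(S)NC1c1cccc([N+](=O)[O-])c1`: 96500 nM
Compound 2 `CCOC(=O)C1=C(C)NC(=S)NC1c1ccc(O)c([N+](=O)[O-])c1`: > 100000 nM

Compound 2 stands at the top end of what this assay can report. Its > 100000 nM is a limit of the assay and not a number. Among the measured compounds shown here, compound 1 gives 96500 nM, so neither measured compound shows strong inhibition, and no step between the two can be read from these values.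

Compound 3 `CCOC(=O)C1=C(C)NC(=S)NC1c1ccc(O)c(OC)c1` carries methoxy in place of nitro on an aromatic carbon, ortho to a hydroxy group (methoxy in place of nitro on an aromatic carbon). The rest of compound 2 stays unchanged. For the measured compounds named here, with compound 1 at 96500 nM as the only true number available, nothing points to a large gain. In this assay the expected change is therefore small, at best a modest shift toward stronger inhibition and quite possibly none beyond the scatter. Another limit reading would be no surprise.

For compound 3 the estimated value is 90000 nM, with an expected range from 35000 nM to 180000 nM. This estimate means an expected step of an at least 1.1-fold lower number from compound 2 to compound 3 (0.04 log units; that floor lies within the scatter).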

Compound 3, half-maximal inhibitory concentration: > 100000 nM
Compound 3 was reported as a limit; the forecaster's own chance of this, stated with the estimate: 50%; at least 1.1-fold (0.04 log units) between middle value and limit.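

Compound 2 and compound 3 both sit at a limit and not at a number in this assay, so no step can be read between them: the limit of > 100000 nM in this assay, at which 2 of the 3 values shown sit.

The compounds shown leave open whether methoxy in place of nitro on an aromatic carbon changes the antiproliferative activity at all, and in which direction.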